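Swapping one ring group: what compound 3 may show

A few compounds are considered here, and "the series" means these few. Any claim that something is new, unique, unknown or untested is made for them only; others in the source may bear on it.

compound 1 `Nc1nc(N)c2cc(CSC(=S)N3CCN(c4ccc(Cl)c(Cl)c4)CC3)ccc2n1` gives 2370 nM
compound 2 `Nc1nc(N)c2cc(CSC(=S)N3CCN(c4ccccc4[N+](=O)[O-])CC3)ccc2n1` gives 4350 nM

In a functional assay on MCF7 cells (Homo sapiens) for antiproliferative activity, read by MTT assay, with a stated time of 72 h (on this read-out lower numbers stand for stronger inhibition and higher numbers for weaker inhibition), compound 2 gives 4350 nM and compound 1 gives 2370 nM so the two values lie within the usual scatter of each other. Compound 3 `Nc1nc(N)c2cc(CSC(=S)N3CCN(c4ccccn4)CC3)ccc2n1` keeps the shared core and differs from compound 2 in one group (pyridin-2-yl in place of 2-nitrophenyl on an amine nitrogen in a ring): pyridin-2-yl in place of 2-nitrophenyl on an amine nitrogen in a ring. Among the measured compounds shown here, one measured step bears on this, at the same place: 2-nitrophenyl in place of 3,4-dichlorophenyl gave a 1.8-fold higher number from compound 1 to compound 2 (0.26 log units; within the scatter) and so stayed within the scatter. For the measured compounds named here, one step is thin evidence and no measured compound carries pyridin-2-yl, so no step beyond the scatter is expected in this assay in either direction. The estimated step (a 1.1-fold lower number from compound 2 to compound 3 (0.04 log units; within the scatter)) stays within that scatter. For compound 3 the estimated value is 4000 nM with a likely range from 1500 nM to 10000 nM for a single measurement.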

Compound 3, half-maximal inhibitory concentration: 5110 nM
The estimate for compound 3 lay 1.3-fold (0.11 log units) below the measured number; low and high end bracket the measured number.
By their numbers in this assay, from the lowest: compounds 1, 2 and 3 (each within the scatter of the next, the first and the last beyond it).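

In this assay, exchanging 2-nitrophenyl for pyridin-2-yl, a smaller group with a nitrogen in its aromatic ring, gives a 1.2-fold higher number from compound 2 to compound 3 (0.07 log units; within the scatter), so this further change on the amine nitrogen leaves the read-out effectively unchanged. Among the compounds shown here, the comparison with 3,4-dichlorophenyl gives the first step at this position that clears the scatter, a 2.2-fold higher number from compound 1 to compound 3 (0.33 log units; beyond the scatter), which shows that the group here can affect the read-out, though only modestly. No supporting measurement is available to explain this difference.

The compounds shown leave open whether plain phenyl or 4-chlorophenyl on this nitrogen would give a number closer to that of compound 1 or compound 3. They also leave open how a non-aromatic group, such as cyclohexyl or benzyl, would behave here.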